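Swapping Benzoyl for a Carbamoylethyl Chain on the Amine

This account rests on a few compounds, and the source may have more. Where it says the series, first, only, none or still open, it means among the compounds named here.

Compound 2 `Cc1cn([C@@H]2O[C@H](CO[Si](C)(C)C(C)(C)C)[C@@]3(OS(=O)(=O)C=C3NC(=O)c3ccccc3)[C@H]2O[Si](C)(C)C(C)(C)C)c(=O)n(C)c1=O` carries a benzoyl group on the amine nitrogen. In a functional assay on HEL cells (Homo sapiens) for cytotoxicity, read by microscopy (a lower number here means that less compound is tolerated, a higher number that more compound is tolerated), compound 2 gives only a limit, >= 3200 nM. The other compound measured in this assay is compound 1 `Cc1cn([C@@H]2O[C@H](CO[Si](C)(C)C(C)(C)C)[C@@]3(OS(=O)(=O)C=C3NCCC(=O)OCc3ccccc3)[C@H]2O[Si](C)(C)C(C)(C)C)c(=O)n(C)c1=O`. Compound 1 likewise gives only a limit, >= 400000 nM. The step that the two limits leave unreadable from compound 1 to compound 2 therefore cannot be read, since both the limit of >= 3200 nM in this assay, at which 1 of the 2 values shown sits, and the limit of >= 400000 nM in this assay, at which 1 of the 2 values shown sits, are limits rather than numbers. Compound 3 `Cc1cn([C@@H]2O[C@H](CO[Si](C)(C)C(C)(C)C)[C@@]3(OS(=O)(=O)C=C3NCCC(N)=O)[C@H]2O[Si](C)(C)C(C)(C)C)c(=O)n(C)c1=O` differs from compound 2 by 2-carbamoylethyl in place of benzoyl on an amine nitrogen. No readable measured step bears on this change, so its size is open. Compound 1, which also carries a chain rather than a ring on that nitrogen, reached >= 400000 nM in this assay. For compound 3 the estimated value is 100000 nM, with an expected range from 3200 nM to 400000 nM, most likely reported again as a limit. The expected step is a step that the limit leaves unreadable from compound 2 to compound 3.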

Compound 3, minimum cytotoxic concentration: >= 80000 nM
Compound 3 gave a limit, no number; the forecaster's own chance of this, stated with the estimate: 70%; the middle value does not contradict the limit.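

In this assay compound 3 gives >= 80000 nM, which is a limit and not a number. Compound 1 and compound 2 are limits too, so no step among these three compounds can be read. The compounds shown leave open how much the tolerated concentration changes with any of these groups on the amine nitrogen.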